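The compounds below may be only part of what the source reports. "The series", "measured", "known", "first", "only" and "open" are said of these compounds alone.

In a functional assay on CHO cells for agonist activity at Free fatty acid receptor 1 (Homo sapiens), read by FLIPR and calcium flux (on this read-out higher numbers stand for an effect only at larger amounts of compound and lower numbers for an effect already at smaller amounts), compound 1 `O=C(O)CS(=O)(=O)c1cccc(OCc2ccc(-c3ccccc3)cc2)c1` gives > 1000 nM, which is a limit of the assay rather than a number. Compound 2 `Cc1ccccc1-c1ccc(COc2cccc(S(=O)(=O)CC(=O)O)c2)cc1` carries methyl in place of hydrogen on an aromatic carbon and in this assay gives > 1000 nM, again only a limit. The step that the two limits leave unreadable from compound 1 to compound 2 therefore cannot be sized, since the limit of > 1000 nM in this assay, at which 2 of the 3 values shown sit, holds for both. Compound 3 `Cc1noc(C)c1-c1cccc(COc2ccc(S(=O)(=O)CC(=O)O)cc2)c1` has a different core; the difference between the two cores is not broken down here. In this assay compound 3 gives 269 nM. Compound 4 `Cc1ccc(-c2c(C)noc2C)cc1COc1ccc(S(=O)(=O)CC(=O)O)cc1` is still to be measured and differs from compound 3 by methyl in place of hydrogen on an aromatic carbon, the same kind of change as before, though here the place is also para to a 3,5-dimethyl-1,2-oxazol-4-yl group. With the earlier step unreadable, compound 3 and its 269 nM are the only anchor, and the change is expected to give a small step of a 1.3-fold lower number from compound 3 to compound 4 (0.13 log units; within the scatter). Compound 4 is thus expected near 200 nM, within 70 nM to 700 nM.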

Compound 4, half-maximal effective concentration: 427 nM
Compound 4: the middle estimate sits 2.1-fold (0.33 log units) below what was measured; low and high end bracket the measured number.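

In this assay, methyl in place of hydrogen on an aromatic carbon gives a 1.6-fold higher number from compound 3 to compound 4 (0.20 log units; within the scatter), so on this core, with the methyl ortho to a large group, the change makes no difference that can be told from scatter. This is a single readable step on a single core, so it does not show whether the result carries over to another core. The same kind of change on the core of compound 1 cannot be read, because compound 1 and compound 2 both sit at a limit of the assay rather than at a number: the limit of > 1000 nM in this assay, at which 2 of the 4 values shown sit.

From the compounds shown here alone, what a methoxy group, an amine or a longer chain would give at this place on the ring remains open.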